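Carbamate to methoxy on the fused core: expected inhibition

This account rests on a few compounds, and the source may have more. Where it says the series, first, only, none or still open, it means among the compounds named here.

Measured so far:
compound 1 `Cc1cc(OCc2ccccc2)c2nc(C)c(N)n2c1` — 65%
compound 2 `COC(=O)Nc1c(C)nc2c(OCc3ccccc3)cccn12` — 0%

In a functional assay on the whole organism with Rattus norvegicus as the target, at a dose of 40 mg/kg by the intraperitoneal route (on this read-out lower numbers stand for less inhibition and higher numbers for more inhibition at the one dose given (going by the name of the read-out)), compound 1 gives 65%, while compound 2 gives 0%. Compound 2 thus stands lowest of the two numbers; its nearest neighbour, compound 1, lies higher by a gap well beyond the scatter. The two differ in more than one place, so no single step can be read from them, and nothing is known about how the group on the five-membered ring alone shifts the read-out.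

Compound 3 `COc1c(C)nc2c(OCc3ccccc3)cccn12` is not yet measured. Its change from compound 2: methoxy in place of (methoxycarbonyl)amino on an aromatic carbon. With compound 2 at the floor of the read-out, no downward move is available. The step of a number 20 percentage points higher from compound 2 to compound 3 (beyond the scatter) is expected to be upward and modest, possibly not beyond the scatter. Compound 3 is therefore expected to give 20%, in a range from 0% to 50%.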

Compound 3, a percentage reported as inhibition, in the whole organism at one dose (the size of the read-out at that dose, not a potency): 49%
The estimate for compound 3 lay 29 percentage points below the measured number, within the range that was stated.
By their numbers in this assay, from the lowest: compound 2; then compound 3; then compound 1.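

In this assay, activity at this position does not depend on the (methoxycarbonyl)amino group: replacing it with methoxy on the aromatic carbon of the five-membered ring gives a number 49 percentage points higher from compound 2 to compound 3 (beyond the scatter). Among these compounds, this is the first single-place comparison at this carbon, and it shows that the group carried there can decide between no measurable inhibition and a clear response, even with the rest of the structure held constant. The change removes the hydrogen-bond donor and the double bond outside the aromatic rings and leaves a smaller group, but nothing available explains the step.

Which of these differences matters remains open, as this single step changes them together. An ethoxy or hydroxy group at the same carbon would test how far the response depends on the attached chain and its oxygen.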